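Capping the Ring Nitrogen of a Pyrazoline

The source may hold more compounds than are shown below. What is called first, only, known or untested is meant among the compounds shown, and "the series" means these compounds.

Of the compounds shown here, three have been measured in a functional assay on NCI-H1975 cells (Homo sapiens) for inhibition, read by sulforhodamine B assay, tested at 10 uM; on this read-out higher numbers stand for more inhibition at the one concentration tested (going by the name of the read-out) and lower numbers for less inhibition. Compound 1, `CN(C)c1ccc(C2CC(c3ccc(-n4cncn4)cc3)=NN2)cc1`, gives -3.3%, the lowest of the three numbers. Compound 2, `CN(C)c1ccc(C2CC(c3ccc(-n4ccnc4)cc3)=NN2)cc1`, gives 0.1%; the step of a number 3.4 percentage points higher from compound 1 to compound 2 (within the scatter) lies within the scatter. Compound 3, `Cc1ccc(S(=O)(=O)N2N=C(c3ccc(N4CCN(C)CC4)cc3)CC2c2ccc(N(C)C)cc2)cc1`, gives 38.1%, a number well beyond the scatter above compound 1, but compound 3 differs from compound 1 in more than one place, so no single step can be read from the pair.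

Compound 4, `CN(C)c1ccc(C2CC(c3ccc(-n4cncn4)cc3)=NN2C(=O)c2ccc(F)cc2)cc1`, has not yet been measured. It differs from compound 1 in one place: (4-fluorophenyl)carbonyl in place of hydrogen on an amine nitrogen in a ring. Among the compounds with values here, none of the measured steps touches this position: the step from compound 1 to compound 2 concerns the aromatic five-membered ring at the far end of the molecule, and compound 3 carries a different group on the same ring nitrogen together with a second change elsewhere. Within the data shown here, the only hint is that the one measured compound bearing a group on that nitrogen, compound 3, gives a clearly higher number than compound 1 and compound 2. On that thin basis a modest rise is expected, as a number 18.3 percentage points higher from compound 1 to compound 4 (beyond the scatter), though the data do not rule out no change beyond the scatter. Compound 4 is therefore estimated at 15%, within a range from -5% to 40%.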

Compound 4, a percentage reported as inhibition, at one concentration (the size of the read-out at that concentration, not a potency): -1.1%
Compound 4: the middle estimate sits 16.1 percentage points above what was measured, within the range that was stated.
By their numbers in this assay, from the lowest: compounds 1, 4 and 2 (each within the scatter of the next); then compound 3.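

In this assay, placing (4-fluorophenyl)carbonyl on the amine nitrogen in the ring gives a number 2.2 percentage points higher from compound 1 to compound 4 (within the scatter) and so leaves the reading indistinguishable from that of the unsubstituted nitrogen. Within the data shown here, this is the first direct look at this position, and it shows that capping the nitrogen with this aromatic carbonyl group is not enough on its own to produce measurable inhibition at the one concentration tested. Nothing available explains why the reading stays flat.

The steps from compound 3 to the other compounds cannot be read, since compound 3 differs from each of them in more than one place, so its 38.1% cannot be assigned to the group on the ring nitrogen or to the change elsewhere in the molecule. As far as these compounds go, it remains open whether a sulfonyl link at this nitrogen matters, and whether a small acetyl group or a longer chain ending in an amine would behave like (4-fluorophenyl)carbonyl or move the number.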